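The source may report more compounds than this note shows. Statements on the series, on what has been measured and on what is new or still open speak of the compounds shown alone.

Three compounds share one core and differ only in the group carried on an aromatic nitrogen. In a functional assay on HepG2 cells (Homo sapiens) for inhibition, read by MTT assay, with a stated time of 72 h (on this read-out lower numbers stand for stronger inhibition and higher numbers for weaker inhibition), compound 1 `N#Cc1cccc(-n2cc(COc3cccc(NC(=O)Nc4ccc(Cl)c(C(F)(F)F)c4)c3)nn2)c1` gives 2760 nM, compound 2 `CC(C)c1ccccc1-n1cc(COc2cccc(NC(=O)Nc3ccc(Cl)c(C(F)(F)F)c3)c2)nn1` gives 1900 nM, and compound 3 `O=C(Nc1cccc(OCc2cn(-c3ccc(Cl)cc3)nn2)c1)Nc1ccc(Cl)c(C(F)(F)F)c1` gives 2490 nM. Compound 3 holds the second highest of these three numbers, yet both gaps are within the scatter: a 1.1-fold lower number from compound 1 to compound 3 (0.04 log units; within the scatter) and a 1.3-fold higher number from compound 2 to compound 3 (0.12 log units; within the scatter). Compound 4 `O=C(Nc1cccc(OCc2cn(-c3ccc(I)cc3)nn2)c1)Nc1ccc(Cl)c(C(F)(F)F)c1` differs from compound 3 by iodo in place of chloro on an aromatic carbon. For the measured compounds named here, no measured step replaces a chloro in this way; the known steps, including a 1.5-fold lower number from compound 1 to compound 2 (0.16 log units; within the scatter), exchange the whole group on the aromatic nitrogen and stay within the scatter. Compound 4 is therefore expected to show no step beyond the scatter, a 1.0-fold higher number from compound 3 to compound 4 (0.00 log units; within the scatter). In this assay compound 4 is estimated at 2500 nM, with a range from 1200 nM to 5200 nM.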

Compound 4, half-maximal inhibitory concentration: 2690 nM
The estimate for compound 4 lay 1.1-fold (0.03 log units) below the measured number; the range from low to high includes it.
By their numbers in this assay, from the lowest: compounds 2, 3, 4 and 1 (each within the scatter of the next).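

Iodo in place of chloro, a change on the ring carried by the aromatic nitrogen rather than an exchange of the whole group, gives in this assay a 1.1-fold higher number from compound 3 to compound 4 (0.03 log units; within the scatter) and so leaves the number unmoved at this place, para to a large group. The 4-iodophenyl compound also stays level with the other two groups, showing a 1.4-fold higher number from compound 2 to compound 4 (0.15 log units; within the scatter) and a 1.0-fold lower number from compound 1 to compound 4 (0.01 log units; within the scatter) within the same narrow band. Nothing measured here bears on why this swap changes so little. On these data alone, whether an amine or a carboxylic acid at this same place would move the number beyond the scatter stays open.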